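Sulfur-linked isomers in the shared core series

The compounds below may be only part of what the source reports. "The series", "measured", "known", "first", "only" and "open" are said of these compounds alone.

Compound 1 `Cn1ncc2c(=O)n(-c3ccccc3)c(SC(C)(C)c3ccccc3)nc21`: 1390 nM
Compound 2 `Cn1ncc2c(=O)n(-c3ccccc3)c(CNc3cccc(F)c3)nc21`: 1050 nM

In an assay on isolated protein for inhibition of Retinaldehyde dehydrogenase 3 (Homo sapiens) (a lower number here means a stronger inhibitor, a higher number a weaker inhibitor), compound 1 shows the highest of the two numbers, but compound 2 lies within the scatter of it, so no order between the two is drawn. Compound 3 `CCC(Sc1nc2c(cnn2C)c(=O)n1-c1ccccc1)c1ccccc1` has the same atoms as compound 1, joined differently: 1-phenylpropyl in place of 1-methyl-1-phenylethyl on a sulfur. Within the data shown here, no step between two measured compounds covers such a rearrangement, so nothing beyond the scatter is expected in this assay, in either direction. Compound 3 is estimated at 1200 nM, within 450 nM to 3200 nM, an expected step of a 1.2-fold lower number from compound 1 to compound 3 (0.06 log units; within the scatter) of no size beyond the scatter.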

Compound 3, half-maximal inhibitory concentration: 119 nM
Compound 3: the middle estimate sits 10-fold (1.00 log units) above what was measured; measured number below the stated range.
By their numbers in this assay, from the lowest: compound 3; then compounds 2 and 1 (each within the scatter of the next).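

At the position on a sulfur, the two isomeric groups are not interchangeable in this assay: 1-phenylpropyl in place of 1-methyl-1-phenylethyl gives a 12-fold lower number from compound 1 to compound 3 (1.07 log units; beyond the scatter). The earlier compounds shown here gave no reading of this position, and this pair shows that it responds strongly to how the same atoms are joined. No available measurement accounts for the step.

The pair cannot separate the effect of the ethyl chain from that of removing one of the two methyl groups. A 1-phenylethyl or 1-phenylbutyl group at this position would test how the number depends on chain length.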